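This account rests on a few compounds, and the source may have more. Where it says the series, first, only, none or still open, it means among the compounds named here.

The three measured compounds and their values:

Compound 1, `COC(=O)[C@@]1(C)CC[C@@H]2C3=C1CC[C@@H](C)[C@]3(C)C[C@@H]1c3cc(Br)ccc3N[C@H]21`: 45000 nM
Compound 2, `COC(=O)[C@@]1(C)CC[C@@H]2C3=C1CC[C@@H](C)[C@]3(C)C[C@@H]1c3cc(OC)ccc3N[C@H]21`: 25000 nM
Compound 3, `COC(=O)[C@@]1(C)CC[C@@H]2C3=C1CC[C@@H](C)[C@]3(C)Cc1c2[nH]c2ccc(Br)cc12`: 12000 nM

All three were tested in a functional assay on SW1573 cells (Homo sapiens) for inhibition, read by sulforhodamine B assay, with a stated time of 48 h; a lower number here means a stronger inhibitor of growth, a higher number a weaker inhibitor of growth. Compound 1 and compound 2 share one core and differ in a single change, (methoxy in place of bromo on an aromatic carbon). That change gave a 1.8-fold lower number from compound 1 to compound 2 (0.26 log units; within the scatter), so the two values do not separate in this assay. Compound 3 has a different core; the difference between the core of compound 1 and that of compound 3 is not broken down here. Compound 3 gives the lowest value of the three, with compound 2 giving a higher number beyond the scatter and compound 1 a number higher still.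

Compound 4, `COC(=O)[C@@]1(C)CC[C@@H]2C3=C1CC[C@@H](C)[C@]3(C)Cc1c2[nH]c2ccc(OC)cc12`, has not yet been measured. It arises from compound 3 by the same change, (methoxy in place of bromo on an aromatic carbon), described in the same words for the place. Going by the values given here, the only guide to its effect is the step from compound 1 to compound 2 in this assay. Since that step was within the scatter, compound 4 is expected to lie close to compound 3, with an estimated step of a 1.6-fold lower number from compound 3 to compound 4 (0.20 log units; within the scatter), resting on a 1.8-fold lower number from compound 1 to compound 2 (0.26 log units; within the scatter). On that basis compound 4 is expected to give about 7500 nM in this assay, most likely between 3000 nM and 20000 nM.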

Compound 4, concentration for 50% growth inhibition: 5900 nM
Compound 4: middle estimate off by 1.3-fold (0.10 log units), on the high side, within the range that was stated.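

In this assay, methoxy in place of bromo on an aromatic carbon gave a 2.0-fold lower number from compound 3 to compound 4 (0.31 log units; beyond the scatter), a modest step that stands clear of the scatter on this core. Set beside the same change on the core of compound 1, the two steps cannot be told apart, so in these two pairs the change carried from one core to the other with much the same size and in the same direction: the same change on two cores in this assay, a 1.8-fold lower number (0.26 log units; within the scatter) from compound 1 to compound 2 and a 2.0-fold lower number (0.31 log units; beyond the scatter) from compound 3 to compound 4, 1.1-fold (0.05 log units) apart, within the scatter of two such steps This rests on only two pairs in a single assay, and the step on the core of compound 1 does not by itself separate its two values, so it sets no rule for other cores or other cell lines and gives no reason why the numbers move as they do.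

The compounds shown carry only bromo or methoxy at this place on the six-membered aromatic ring, which leaves open how a hydroxyl, an amine or a longer alkoxy chain there would behave on either core. From the compounds shown here alone, all four also keep the same methyl ester, so the effect of a carboxylic acid or an amide in its place on these values remains open too.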